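The compounds below may be only part of what the source reports. "The series", "measured", "known", "first", "only" and "open" are said of these compounds alone.

Measured compounds:
Compound 1 `N#CC1=C(N)Oc2c(c3nc4ccccc4nc3c3ccccc23)C12C(=O)N(Cc1cnnn1-c1ccc(S(N)(=O)=O)cc1)c1ccccc12` — in a functional assay on HepG2 cells (Homo sapiens) for antiproliferative activity, read by MTT assay, with a stated time of 48 h (on this read-out higher numbers stand for weaker inhibition and lower numbers for stronger inhibition), compound 1 gives 42200 nM.
Compound 2 `N#CC1=C(N)Oc2c(c3nc4ccccc4nc3c3ccccc23)C12C(=O)N(Cc1cnnn1-c1ccc(Cl)c(Cl)c1)c1ccccc12` — in this assay compound 2 reaches only the limit > 50000 nM, not a number.
Compound 3 `Cc1ccccc1-n1nncc1CN1C(=O)C2(C(C#N)=C(N)Oc3c(N)cc4nc5ccccc5nc4c32)c2ccccc21` — in this assay compound 3 likewise reaches only the limit > 50000 nM.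

Compound 3 therefore stands where the measurement stops: the limit of > 50000 nM in this assay, at which 2 of the 3 values shown sit, marks where it sits, together with compound 2, while compound 1 alone delivers a number, and that number is itself very weak inhibition.

Compound 4 `N#CC1=C(N)Oc2c(N)cc3nc4ccccc4nc3c2C12C(=O)N(Cc1cnnn1-c1ccc(Cl)cc1)c1ccccc12` differs from compound 3 in one place: 4-chlorophenyl in place of 2-methylphenyl on an aromatic nitrogen. Within the data shown here, the only measured step that resembles this change is an at least 1.1-fold higher number from compound 1 to compound 2 (0.07 log units; that floor lies within the scatter), which also swaps the phenyl group on the aromatic nitrogen of the triazole ring. That step is a floor, not a full number, and it lies within the scatter, so it points to no real movement. Compounds 1 and 2 share a core that is not quite the core of compound 3, so the comparison is loose. Nothing in the measured data suggests that exchanging one phenyl group for another on this aromatic nitrogen moves the read-out beyond the scatter.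

For compound 4 the expected result in this assay is 50000 nM, within 25000 nM to 100000 nM. This estimate means a step of a number no higher from compound 3 to compound 4 (the limit leaves the size open), that is, no change beyond the scatter, with a strong chance that compound 4 again returns only a limit.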

Compound 4, half-maximal inhibitory concentration: > 50000 nM
Compound 4: only a limit was reported (the forecaster's own chance of this, stated with the estimate: 70%); the middle value sits exactly at the limit.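

Compound 3 and compound 4 both return only a limit in this assay, so the step between them cannot be read. The compounds shown leave open how strongly either one inhibits, and whether 2-methylphenyl and 4-chlorophenyl differ at all on this aromatic nitrogen, as most of the set stops at one point: the limit of > 50000 nM in this assay, at which 3 of the 4 values shown sit.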